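Trifluoromethoxy for trifluoromethyl: notes toward compound 3

The compounds below may be only part of what the source reports. "The series", "measured", "known", "first", "only" and "open" are said of these compounds alone.

Compound 1 `Oc1ccccc1-c1cc(-c2ccc(F)cc2)cc(-c2ccccc2O)n1` has been run in a functional assay on HeLa cells (Homo sapiens) for inhibition; a lower number here means a stronger inhibitor, a higher number a weaker inhibitor. For compound 1 the result is a limit of the assay, not a number: > 50000 nM. Compound 2 `Oc1ccccc1-c1cc(-c2ccc(C(F)(F)F)cc2)cc(-c2ccccc2O)n1` carries trifluoromethyl in place of fluoro on an aromatic carbon. For compound 2 the result in this assay is likewise a limit and not a number: > 50000 nM. The step that the two limits leave unreadable from compound 1 to compound 2 therefore cannot be read, since both ends are limits. Where compound 2 stands is given only by the limit of > 50000 nM in this assay, at which 2 of the 2 values shown sit; no value for it exists as a number.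

Compound 3 `Oc1ccccc1-c1cc(-c2ccc(OC(F)(F)F)cc2)cc(-c2ccccc2O)n1` is not yet measured. It differs from compound 2 by trifluoromethoxy in place of trifluoromethyl on an aromatic carbon. Within the data shown here, the only measured step that bears on a change at this place is a step that the two limits leave unreadable from compound 1 to compound 2, and its size is not readable, so neither a direction nor a size can be drawn from it. Nothing in the series points to a number below the limit. Compound 3 is therefore expected to remain at or near the limit, with the step that the limit leaves unreadable from compound 2 to compound 3 expected to stay within the scatter. The estimate for compound 3 in this assay is 80000 nM, with a range from 30000 nM to 300000 nM.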

Compound 3, half-maximal inhibitory concentration: > 50000 nM
Compound 3 ended at the assay's limit; the forecaster's own chance of this, stated with the estimate: 85%; the middle value does not contradict the limit.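

With compound 3 also at a limit of the assay, the steps from compound 2 to compound 3 and from compound 1 to compound 3 cannot be read in this assay, since all of their ends are limits: the limit of > 50000 nM in this assay, at which 3 of the 3 values shown sit.

The compounds shown leave open whether in this assay any group at this place on the shared core gives a number rather than a limit.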